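This account rests on a few compounds, and the source may have more. Where it says the series, first, only, none or still open, it means among the compounds named here.

In a physicochemical assay for solubility, using the shake flask method, measured as kinetic solubility, with a stated time of 20 h, at pH 2 (on this read-out higher numbers stand for higher solubility and lower numbers for lower solubility), compound 3 `FC(F)(F)c1ccc(Nc2cc3[nH]c(C4CCOC4)nc3cn2)nc1` gives 200000 nM, the largest number among the three compounds measured, although compound 2 `FC(F)(F)c1ccc(Nc2cc3[nH]c(C4CCCC4)nc3cn2)nc1` gives 132000 nM, a value within the usual scatter of it. Compound 1 `Fc1ccc(-c2nc3cnc(Nc4ccc(C(F)(F)F)cn4)cc3[nH]2)cc1F` gives 6000 nM. Compound 4 `CC1(c2nc3cnc(Nc4ccc(C(F)(F)F)cn4)cc3[nH]2)CC1` differs from compound 3 by 1-methylcyclopropyl in place of oxolan-3-yl on an aromatic carbon. For the measured compounds named here, two measured steps bear on this change. Replacing an aromatic group with a saturated ring gave a large step: a 33-fold higher number from compound 1 to compound 3 (1.52 log units; beyond the scatter). Swapping one saturated five-membered ring for another did not: a 1.5-fold higher number from compound 2 to compound 3 (0.18 log units; within the scatter). Compound 2 carries cyclopentyl, another ring of carbon only, and gives 132000 nM, so compound 4 is expected to land near it, with a 1.7-fold lower number from compound 3 to compound 4 (0.22 log units; within the scatter). Compound 4 is therefore estimated at 120000 nM, within a range from 50000 nM to 250000 nM.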

Compound 4, solubility: 200000 nM
Beside the measured number, compound 4's estimate is 1.7-fold (0.22 log units) below it, within the range that was stated.
By their numbers in this assay, from the lowest: compound 1; then compounds 2, 3 and 4 (each within the scatter of the next).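

In this assay the change to a ring of carbon only gives no change at the digits printed from compound 3 to compound 4 (within the scatter) and so the ring oxygen of oxolan-3-yl, with its hydrogen-bond acceptor, is not required for the high number. A three-membered ring reads much like a five-membered one, with a 1.5-fold higher number from compound 2 to compound 4 (0.18 log units; within the scatter) and the large gap to the aromatic group now appears with a third non-aromatic ring, with a 33-fold higher number from compound 1 to compound 4 (1.52 log units; beyond the scatter) as the step. From the compounds shown here alone, whether an amine or a carboxylic acid on this aromatic carbon would read the same stays open. No measurement given here explains why these rings read alike.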